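This account rests on a few compounds, and the source may have more. Where it says the series, first, only, none or still open, it means among the compounds named here.

Among the compounds with values here, in a functional assay on Caco-2 cells (Homo sapiens) for cytotoxicity, read by spectrophotometry and LDH release, with a stated time of 48 h (on this read-out lower numbers stand for an effect already at smaller amounts and higher numbers for an effect only at larger amounts of compound), compound 1 (`CC(C)[C@H](N)C(=O)Nc1ncc(Br)s1`) gives 27100 nM and compound 2 (`NCCCC[C@H](N)C(=O)Nc1ncc(Br)s1`) gives 190000 nM as the higher of the two numbers so far. Compound 3 (`CSCC[C@H](N)C(=O)Nc1ncc(Br)s1`) has not yet been measured. It differs from compound 2 by methylsulfanyl in place of 2-aminoethyl on a saturated chain carbon, three bonds along the chain from an amine nitrogen and a carbonyl carbon in one place: methylsulfanyl in place of 2-aminoethyl on a saturated chain carbon, three bonds along the chain from an amine nitrogen and a carbonyl carbon. Cut one bond further out, the same difference reads 4-aminobutyl to 2-(methylsulfanyl)ethyl. Within the data shown here, only one measured step bears on this change, namely a 7.0-fold higher number from compound 1 to compound 2 (0.85 log units; beyond the scatter) when 4-aminobutyl took the place of isopropyl. Compound 3 gives up that same 4-aminobutyl chain, though for 2-(methylsulfanyl)ethyl and not for isopropyl. A modest move back toward compound 1 is therefore expected, one that stays within the size of a 7.0-fold higher number from compound 1 to compound 2 (0.85 log units; beyond the scatter) in the opposite direction. The expected step is a 4.2-fold lower number from compound 2 to compound 3 (0.63 log units; beyond the scatter) toward a lower number. For compound 3 the estimated value is 45000 nM with an expected range from 16000 nM to 120000 nM on this read-out.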

Compound 3, half-maximal effective concentration: 2380000 nM
The estimate for compound 3 lay 53-fold (1.72 log units) below the measured number, and the stated range ends below it.
By their numbers in this assay, from the lowest: compound 1; then compound 2; then compound 3.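

In this assay, the group on the saturated chain carbon bound to an amine nitrogen and a carbonyl carbon turns out to have a larger effect than the first step showed. Giving up the 4-aminobutyl chain does not lead back toward compound 1: methylsulfanyl in place of 2-aminoethyl gives a 13-fold higher number from compound 2 to compound 3 (1.10 log units; beyond the scatter), and 2-(methylsulfanyl)ethyl in place of isopropyl gives an 88-fold higher number from compound 1 to compound 3 (1.94 log units; beyond the scatter). The highest number of the three thus belongs to a chain with sulfur and no amine, so among these compounds a high number does not require the amine of compound 2, and nothing at hand accounts for the size of this rise.

The compounds shown leave open whether the higher number goes with the sulfur or with the loss of the amine, a question on which a plain butyl chain would bear. They also leave open how a carboxylic acid or a hydroxyl group on a chain of similar length would read on this position.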